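The source may hold more compounds than are shown below. What is called first, only, known or untested is meant among the compounds shown, and "the series" means these compounds.

Compound 1 `CC(O)(C(=O)Nc1ccc(S(=O)(=O)c2ccccc2)c(F)c1)C(F)(F)F`: in a functional assay (Cavia porcellus) with sulfonylurea receptors; K-ATP channels (Homo sapiens) as the target (a lower number here means a stronger inhibitor, a higher number a weaker inhibitor), compound 1 gives 1800 nM
Compound 2 `CC(O)(C(=O)Nc1ccc(S(=O)(=O)c2cccc(F)c2)cc1)C(F)(F)F`: in this assay compound 2 gives 3400 nM

Of the two measured compounds, compound 2 carries the highest number, and its nearest neighbour is compound 1, whose value lies within the scatter of the assay, so the two cannot be ranked against each other on these data. The account now moves from compound 2 to compound 3 `CC(O)(C(=O)Nc1ccc(S(=O)(=O)c2cccc(O)c2)cc1)C(F)(F)F`, which is not yet measured. The change is hydroxy in place of fluoro on an aromatic carbon. Among the measured compounds shown here, no pair among the measured compounds shows a step of this kind, so there is nothing in the data to anchor its size or direction. For compound 3 the step of a 1.2-fold higher number from compound 2 to compound 3 (0.07 log units; within the scatter) is therefore expected to stay within the usual scatter, with no clear direction. Compound 3 is estimated at 4000 nM in this assay, with a range from 1500 nM to 11000 nM.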

Compound 3, half-maximal inhibitory concentration: 18000 nM
Compound 3: middle estimate off by 4.5-fold (0.65 log units), on the low side, and the stated range ends below it.
By their numbers in this assay, from the lowest: compounds 1 and 2 (each within the scatter of the next); then compound 3.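

In this assay, among the compounds shown here, putting hydroxy in place of fluoro on this aromatic carbon, meta to a large group, gives a 5.3-fold higher number from compound 2 to compound 3 (0.72 log units; beyond the scatter), the first step that can be read beyond the scatter. It shows that this position is not indifferent to the exchange: the 3-hydroxyphenyl compound is the weaker inhibitor of the pair, and its direction is now fixed for this one change on this one core. Nothing at hand accounts for the size or direction of this step.

On these data alone, it remains open whether a methoxy, an amine or a chlorine at this place would behave more like fluoro or more like hydroxy. As far as these compounds go, it also remains open whether the same exchange would produce a step of similar size on the core of compound 1.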